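The compounds below may be only part of what the source reports. "The series", "measured", "known", "first", "only" and "open" are said of these compounds alone.

Measured compounds:
- compound 1, `O=S(=O)(c1ccccc1)c1nc2ccccc2nc1Nc1ccccc1`: 140 nM
- compound 2, `COc1ccc(Nc2nc3ccccc3nc2S(=O)(=O)c2ccccc2)cc1`: 640 nM
- compound 3, `COc1cc(Nc2nc3ccccc3nc2S(=O)(=O)c2ccccc2)cc(OC)c1`: 50 nM

All three were tested in a functional assay on HL-60 cells (Homo sapiens) for cytotoxicity, read by MTT assay, with a stated time of 72 h; on this read-out higher numbers stand for weaker inhibition and lower numbers for stronger inhibition. Compound 3 gives the lowest number of the three; the nearest is compound 1, with a 2.8-fold lower number from compound 1 to compound 3 (0.45 log units; beyond the scatter), and the furthest is compound 2, with a 13-fold lower number from compound 2 to compound 3 (1.11 log units; beyond the scatter). Compound 4, `COc1cc(Nc2nc3ccccc3nc2S(=O)(=O)c2ccccc2)cc(OC)c1OC`, has not yet been measured. It differs from compound 3 in one place: methoxy in place of hydrogen on an aromatic carbon.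

For the measured compounds named here, two measured steps bear on this change. The step from compound 1 to compound 2 also put a methoxy on an aromatic carbon of the same ring, and it gave a 4.6-fold higher number from compound 1 to compound 2 (0.66 log units; beyond the scatter). The step from compound 1 to compound 3, which put two methoxy groups on that ring, went the other way, with a 2.8-fold lower number from compound 1 to compound 3 (0.45 log units; beyond the scatter). Going by the values given here, the single added methoxy in compound 4 sits on the aromatic carbon between the existing two, para to a large group, the same placement that weakened compound 2 relative to compound 1. A modest rise in the number is therefore expected for compound 4, a 2.4-fold higher number from compound 3 to compound 4 (0.38 log units; beyond the scatter). Compound 4 is estimated at 120 nM, within a range from 40 nM to 400 nM.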

Compound 4, half-maximal inhibitory concentration: 1770 nM
Beside the measured number, compound 4's estimate is 15-fold (1.17 log units) below it, outside the stated range (above it).
By their numbers in this assay, from the lowest: compound 3; then compound 1; then compound 2; then compound 4.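

In this assay, methoxy in place of hydrogen on the aromatic carbon para to a large group gives a 35-fold higher number from compound 3 to compound 4 (1.55 log units; beyond the scatter), and here that carbon is also ortho to two methoxy groups. The earlier compounds shown here showed this change only on a ring with no other methoxy group, and they could not show whether its size would hold once two such groups were present; it does not hold, and the step depends on what else the ring carries: the same change on two cores in this assay, a 4.6-fold higher number (0.66 log units; beyond the scatter) from compound 1 to compound 2 and a 35-fold higher number (1.55 log units; beyond the scatter) from compound 3 to compound 4, 7.7-fold (0.89 log units) apart, beyond the scatter of two such steps. Among the compounds shown, methoxy at this place raises the number on both cores and none goes against that, so the lower number that compound 3 reaches with its two methoxy groups is seen only while this carbon carries hydrogen.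

From the compounds shown here alone, whether a fluorine, a hydroxyl or a methyl on this carbon would raise the number as methoxy does remains open, so the rise cannot yet be tied to methoxy itself rather than to any group at this place. The compounds shown also cannot tell why the same change is so much larger with two methoxy groups on the ring.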